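From compound 2 to compound 3: a phenyl group exchanged

The source may report more compounds than this note shows. Statements on the series, on what has been measured and on what is new or still open speak of the compounds shown alone.

Within the data shown here, in a functional assay on KB cells (Homo sapiens) for antiproliferative activity, read by sulforhodamine B assay, with a stated time of 3 days (a lower number here means that less compound is needed, a higher number that more compound is needed for the effect), compound 2 `CCC1=C(O)c2c(oc(-c3ccc(O)c(C)c3C)cc2=O)C(CC)(CC)C1=O` gives 6.5 uM, the only actual number available so far. In this assay, compound 1 `CCC1=C(O)c2c(oc(-c3ccc(SC)cc3)cc2=O)C(CC)(CC)C1=O` reaches only a limit, > 52.1 uM, and this is a limit of the assay, not a number. Among the measured compounds shown here, the single measured step, an at least 8.0-fold lower number from compound 1 to compound 2 (0.90 log units; beyond the scatter), brings in 4-hydroxy-2,3-dimethylphenyl in place of 4-(methylsulfanyl)phenyl on the shared core.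

Compound 3 `CCC1=C(O)c2c(oc(-c3cc(C)ccc3C)cc2=O)C(CC)(CC)C1=O` differs from compound 2 at that same aromatic carbon, next to the ring oxygen, with 2,5-dimethylphenyl in place of 4-hydroxy-2,3-dimethylphenyl (2,5-dimethylphenyl in place of 4-hydroxy-2,3-dimethylphenyl on an aromatic carbon). Like compound 1, compound 3 has no hydroxy group on this phenyl ring. For the measured compounds named here, the measured step changes more than the hydroxy group, so it is only a loose guide, and no pair yet isolates that group. Even so, the step of an at least 8.0-fold lower number from compound 1 to compound 2 (0.90 log units; beyond the scatter) leads to the expectation of a higher number in this assay, probably by less than that step shows. The expected change is a 2.8-fold higher number from compound 2 to compound 3 (0.44 log units; beyond the scatter). For compound 3 the estimated value is 18 uM, with an expected range from 6 uM to 55 uM.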

Compound 3, concentration for half-maximal effect: 14.5 uM
Estimate against measurement, compound 3: 1.2-fold (0.09 log units) above; the measured number falls inside the stated range.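

Compound 3 shows that a phenyl ring with no hydroxy group at this carbon, next to the ring oxygen, can still give an actual number in this assay, so lacking that group does not by itself bring a compound to the limit. Removing the hydroxy group and moving the methyl groups together costs only a modest amount, a 2.2-fold higher number from compound 2 to compound 3 (0.35 log units; beyond the scatter), while 2,5-dimethylphenyl in place of 4-(methylsulfanyl)phenyl still gives an at least 3.5-fold lower number from compound 1 to compound 3 (0.55 log units; beyond the scatter). Compound 1 is a limit of the assay and not a number, so the second step gives only a bound on the size of the change: the limit of > 52.1 uM in this assay, at which 1 of the 3 values shown sits.

From the compounds shown here alone, the step to compound 3 alters the hydroxy group and the placement of the methyl groups at once, so what each contributes alone remains open. Also open, going by these compounds, is how this position would respond to a phenyl ring bearing an amine or a carboxylic acid, or to a methoxy group in place of the hydroxy group.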